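The source may hold more compounds than are shown below. What is called first, only, known or untested is meant among the compounds shown, and "the series" means these compounds.

Series notes. The shared core carries two 4-methoxyphenyl groups, and the variable group sits on the aromatic carbon next to the ring nitrogen and next to the ring sulfur. Compound 1 `COc1ccc(-c2nc(/N=C(\N)[N+]3(C)CCCCC3)sc2-c2ccc(OC)cc2)cc1` is the point of departure. In a functional assay with Oryctolagus cuniculus as the target (a higher number here means a weaker inhibitor, a lower number a stronger inhibitor), compound 1 reaches only > 1000 nM, which is a limit of the measurement and not a number, sitting at the limit of > 1000 nM in this assay, at which 1 of the 2 values shown sits. Compound 2 `COc1ccc(-c2nc(CNC(=O)C3=NNC(=O)CC3)sc2-c2ccc(OC)cc2)cc1`, with a different side chain at the same place, gives 55 nM in this assay. Among the compounds with values here, no pair of measured compounds differs in a single place, so no measured step size is available. Compound 3 `COc1ccc(-c2nc(C(N)=O)sc2-c2ccc(OC)cc2)cc1` follows from compound 1 by a group of 3 heavy atoms (1 carbon, 1 nitrogen, 1 oxygen; no ring) in place of a group of 10 heavy atoms (7 carbon, 3 nitrogen; one six-membered non-aromatic ring with 1 hetero atom), on an aromatic carbon. Compound 1 offers only a limit, and the step therefore cannot be sized from the shown numbers. The step is expected to run toward stronger inhibition, an at least 3.3-fold lower number from compound 1 to compound 3 (0.52 log units; beyond the scatter). Compound 3 is estimated at 300 nM in this assay, within 60 nM to 3000 nM.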

Compound 3, half-maximal inhibitory concentration: > 1000 nM
Compound 3 ended at the assay's limit; the forecaster's own chance of this, stated with the estimate: 30%; at least 3.3-fold (0.52 log units) between middle value and limit.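

In this assay no step can be read from compound 1 to compound 3, since both values are limits of the assay and not numbers. The compounds shown leave open whether carbamoyl, entering in place of the ring-bearing group of compound 1, shifts inhibition at all.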